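The source may hold more compounds than are shown below. What is called first, only, known or untested is meant among the compounds shown, and "the series" means these compounds.

Working notes on the series.

Compound 1 `Fc1ccc(/C=C\c2cc3ccccc3nc2Cl)cc1` gives 24900 nM in a functional assay on HeLa cells (Homo sapiens) for antiproliferative activity, read by sulforhodamine B assay, with a stated time of 72 h; on this read-out higher numbers stand for weaker inhibition and lower numbers for stronger inhibition. Compound 2 `Fc1ccc(/C=C\c2cc3ccc(Cl)cc3nc2Cl)cc1` carries chloro in place of hydrogen on an aromatic carbon; in this assay compound 2 gives 38600 nM, and the step is a 1.6-fold higher number from compound 1 to compound 2 (0.19 log units; within the scatter). Compound 3 `FC(F)(F)c1cc(/C=C\c2cc3ccccc3nc2Cl)cc(C(F)(F)F)c1` rests on a different core; the difference between the two cores is not broken down here. In this assay compound 3 gives 6780 nM, the lowest of the three numbers, and its gaps to compound 1 and compound 2 lie beyond the scatter.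

Compound 4 `FC(F)(F)c1cc(/C=C\c2cc3ccc(Cl)cc3nc2Cl)cc(C(F)(F)F)c1` is not yet measured. Relative to compound 3 it carries chloro in place of hydrogen on an aromatic carbon, the same change as that from compound 1 to compound 2. Because a 1.6-fold higher number from compound 1 to compound 2 (0.19 log units; within the scatter) stays within the scatter, the expected step is a 1.4-fold higher number from compound 3 to compound 4 (0.15 log units; within the scatter). Compound 4 is therefore estimated at 9500 nM, with a range from 4500 nM to 20000 nM.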

Compound 4, half-maximal inhibitory concentration: 41400 nM
Compound 4: middle estimate off by 4.4-fold (0.64 log units), on the low side, and the stated range ends below it.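

In this assay, chloro in place of hydrogen on an aromatic carbon gives a 6.1-fold higher number from compound 3 to compound 4 (0.79 log units; beyond the scatter), and the step does not carry over at one size from one core to the other: the same change on two cores in this assay, a 1.6-fold higher number (0.19 log units; within the scatter) from compound 1 to compound 2 and a 6.1-fold higher number (0.79 log units; beyond the scatter) from compound 3 to compound 4, 3.9-fold (0.60 log units) apart, beyond the scatter of two such steps

On these two pairs, the size of this step depends on the core, so the step on one core is a poor guide to the step on the other. The two pairs do not show which part of the difference between the cores is responsible, why the steps differ, or whether the same holds on any further core.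

The compounds shown leave open how an amine, a nitrile or a methoxy group in place of the chloro would behave on either core.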